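This account rests on a few compounds, and the source may have more. Where it says the series, first, only, none or still open, it means among the compounds named here.

In a functional assay on CHO cells with adenosine receptor A1 (Homo sapiens) as the target, read by cAMP accumulation and immunoassay, with a stated time of 6 min, tested at 10 uM (on this read-out lower numbers stand for a stronger effect and higher numbers for a weaker effect at the one concentration tested), compound 3, whose structure is `Nc1scc(CN2CCN(c3ccc([N+](=O)[O-])cc3)CC2)c1C(=O)c1ccc(Cl)cc1`, gives -17%. That is the highest of the three numbers recorded: compound 2, `COc1ccc(N2CCN(Cc3csc(N)c3C(=O)c3ccc(Cl)cc3)CC2)cc1`, gives -52%, and compound 1, `Nc1scc(CN2CCN(c3cccc(Cl)c3Cl)CC2)c1C(=O)c1ccc(Cl)cc1`, gives -77%. Compound 4, `Nc1scc(CN2CCN(c3cccnc3)CC2)c1C(=O)c1ccc(Cl)cc1`, has not been measured in this assay. It differs from compound 3 in one place: pyridin-3-yl in place of 4-nitrophenyl on an amine nitrogen in a ring.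

Among the compounds with values here, three measured steps bear on this change, since each of them also swaps the group on the same ring nitrogen: a number 60 percentage points higher from compound 1 to compound 3 (beyond the scatter), a number 35 percentage points higher from compound 2 to compound 3 (beyond the scatter) and a number 25 percentage points higher from compound 1 to compound 2 (beyond the scatter). All three lie beyond the scatter, so this position is one where a change of aryl group moves the read-out considerably. Within the data shown here, no measured compound carries pyridin-3-yl at this place, so the direction of the step can only be guessed from the spread of the three values. Compound 4 is expected to give -40%, within a range from -75% to -5%. The step of a number 23 percentage points lower from compound 3 to compound 4 (beyond the scatter) is thus estimated to be downward, of modest to large size, but with wide uncertainty.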

Compound 4, a percentage reported as activity, at one concentration (the size of the read-out at that concentration, not a potency): -23%
Compound 4: middle estimate off by 17 percentage points, on the low side; measured number inside the range.
By their numbers in this assay, from the lowest: compound 1; then compound 2; then compounds 4 and 3 (each within the scatter of the next).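

In this assay the change from 4-nitrophenyl to pyridin-3-yl gives a number 6 percentage points lower from compound 3 to compound 4 (within the scatter) and so shows that, at this ring nitrogen, two aryl groups differing in size and ring atoms can give read-outs that cannot be told apart. The other two comparisons, a number 29 percentage points higher from compound 2 to compound 4 (beyond the scatter) and a number 54 percentage points higher from compound 1 to compound 4 (beyond the scatter), leave the 4-methoxyphenyl and 2,3-dichlorophenyl compounds clearly apart from compound 4, as they already stood apart from compound 3. No evidence is available on what lies behind these numbers.

Still open, as far as these compounds go, is how plain phenyl or pyridin-4-yl would read at this place, and whether a single chlorine on the phenyl ring would bring the number close to that of compound 1. Also open, from the compounds shown here alone, is what a benzyl group on the same ring nitrogen would do.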